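From compound 3 to compound 4

A few compounds are considered here, and "the series" means these few. Any claim that something is new, unique, unknown or untested is made for them only; others in the source may bear on it.

In a physicochemical assay for lipophilicity (a higher number here means a more lipophilic compound, a lower number a more polar compound), compound 3 (`O=S(=O)(Nc1nccs1)c1ccc2c(c1)OCC[C@@H]2c1ccc(C(F)(F)F)cc1N1CCNCC1`) gives 1.4, the lowest of the three numbers, against compound 2 (`O=C1OCCN1c1cc(C(F)(F)F)ccc1[C@H]1CCOc2cc(S(=O)(=O)Nc3nccs3)ccc21`) at 2.1 and compound 1 (`O=S(=O)(Nc1ncccn1)c1ccc2c(c1)OCC[C@@H]2c1ccc(C(F)(F)F)cc1-c1ccc(F)nc1`) at 2.8. Compound 4 (`O=S(=O)(Nc1nccs1)c1ccc2c(c1)OCC[C@@H]2c1ccc(C(F)(F)F)cc1-c1ccc(F)nc1`) is still unmeasured. The change is 6-fluoropyridin-3-yl in place of piperazin-1-yl on an aromatic carbon, in words 6-fluoropyridin-3-yl in place of piperazin-1-yl on an aromatic carbon. Going by the values given here, the one measured step that brings in piperazin-1-yl at this place is a number 0.70 log units lower from compound 2 to compound 3 (beyond the scatter), modest but beyond the scatter. Differing from compound 4 elsewhere, compound 1 carries 6-fluoropyridin-3-yl at this place and stands at 2.8. A larger upward step is therefore expected, estimated as a number 1.30 log units higher from compound 3 to compound 4 (beyond the scatter). Compound 4 is expected at 2.7, with an estimated range of 2.3 to 3.1.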

Compound 4, distribution coefficient: 3.2
For compound 4 the middle estimate is 0.50 log units below the measured one; the measured number lies above the stated range.
By their numbers in this assay, from the lowest: compound 3; then compound 2; then compound 1; then compound 4.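

Within this assay 6-fluoropyridin-3-yl on this aromatic carbon gives a number 1.80 log units higher from compound 3 to compound 4 (beyond the scatter) against piperazin-1-yl and a number 1.10 log units higher from compound 2 to compound 4 (beyond the scatter) against 2-oxo-1,3-oxazolidin-3-yl, so it reads above both groups with the rest of the molecule unchanged. The sulfonamide nitrogen matters too: 1,3-thiazol-2-yl in place of pyrimidin-2-yl gives a number 0.40 log units higher from compound 1 to compound 4 (beyond the scatter) with 6-fluoropyridin-3-yl held fixed. Still open is where a carboxylic acid or an open-chain amine on this aromatic carbon would fall in this assay among these groups. Nothing available explains the size of these steps.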